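This account rests on a few compounds, and the source may have more. Where it says the series, first, only, none or still open, it means among the compounds named here.

Values in a functional assay on MCF7 cells (Homo sapiens) for cytotoxicity, read by MTT assay, with a stated time of 24 h; a higher number here means a weaker inhibitor, a lower number a stronger inhibitor

Compound 1 `COc1cc2ncnc(Nc3ccc(F)c(Cl)c3)c2cc1OCCCSc1nc2ccccc2s1` gives 5370 nM
Compound 2 `CCc1cc(Br)ccc1Nc1ncnc2cc(OC)c(OCCCSc3nc4ccccc4s3)cc12` gives 5870 nM
Compound 3 `COc1ccc(Nc2ncnc3cc(OC)c(OCCCSc4nc5ccccc5s4)cc23)cc1` gives 14200 nM

Compound 3, at 14200 nM, has the highest number of the three and is therefore the weakest inhibitor so far. Compound 4 `CCCCc1nc(Cl)c(C=O)n1CCCOc1cc2c(Nc3ccc(OC)cc3)ncnc2cc1OC` keeps its 4-methoxyphenyl group, and the change lies elsewhere: 2-butyl-4-chloro-5-formyl-1H-imidazol-1-yl in place of (1,3-benzothiazol-2-yl)sulfanyl on a saturated chain carbon, three bonds along the chain from an oxygen on an aromatic ring.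

Among the measured compounds shown here, no measured step touches this part of the molecule. All three steps exchange only the aromatic group on the nitrogen, so they offer a rough sense of scale and no direction. The measurements show a 1.1-fold higher number from compound 1 to compound 2 (0.04 log units; within the scatter), then a 2.6-fold higher number from compound 1 to compound 3 (0.42 log units; beyond the scatter), and a 2.4-fold higher number from compound 2 to compound 3 (0.38 log units; beyond the scatter). These are small steps, but the new change is a large one, so a wide range is sensible. With no evidence for either direction, no shift beyond the scatter is expected as the best guess. The estimated change is a 1.2-fold lower number from compound 3 to compound 4 (0.07 log units; within the scatter). For compound 4 the estimated value is 12000 nM. The expected range for compound 4 runs from 3500 nM to 40000 nM.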

Compound 4, half-maximal inhibitory concentration: 14000 nM
For compound 4 the middle estimate is 1.2-fold (0.07 log units) below the measured one, and the stated range covers the measured number.
By their numbers in this assay, from the lowest: compounds 1 and 2 (each within the scatter of the next); then compounds 4 and 3 (each within the scatter of the next).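

In this assay, putting 2-butyl-4-chloro-5-formyl-1H-imidazol-1-yl in place of (1,3-benzothiazol-2-yl)sulfanyl gives a 1.0-fold lower number from compound 3 to compound 4 (0.01 log units; within the scatter) even though the two groups differ widely. Among the compounds shown here, the earlier steps changed only the aromatic group on the nitrogen, so this is the first look at the position on a saturated chain carbon, three bonds along the chain from an oxygen on an aromatic ring. Here, with the 4-methoxyphenyl group kept, a benzothiazole with sulfur gives way to an imidazole with chlorine and a formyl group, yet the two compounds cannot be told apart in this assay, and no supporting data explain the match.

Going by these compounds, it remains open whether the same swap would read alike with the 3-chloro-4-fluorophenyl group of compound 1. A morpholine or a carboxylic acid at this position, or a longer chain, is also untested in the compounds shown.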